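The compounds below may be only part of what the source reports. "The series", "measured", "known", "first", "only" and "open" are said of these compounds alone.

In a functional assay on PC-3 cells (Homo sapiens) for antiproliferative activity, read by MTT assay, with a stated time of 24 h (on this read-out higher numbers stand for weaker inhibition and lower numbers for stronger inhibition), compound 1 `O=C1O/C(=C\Cn2cc(Cc3ccccc3)nn2)C(OCc2ccccc2)=C1OCc1ccccc1` gives 71300 nM. Compound 2 `CC(C)(C)c1ccc(-c2cn(CCC3(O)NC(=O)C(OCc4ccccc4)=C3OCc3ccccc3)nn2)cc1` gives 43000 nM in this assay, and the two numbers lie within the usual scatter of each other, so neither stands apart. For compound 3 `O=C1NC(O)(CCn2cc(Cc3ccccc3)nn2)C(OCc2ccccc2)=C1OCc1ccccc1` the read-out in this assay is only a limit of the assay, > 100000 nM, recorded as the limit of > 100000 nM in this assay, at which 1 of the 3 values shown sits.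

Within the data shown here, the one measured step that changes a single group is an at least 2.3-fold higher number from compound 2 to compound 3 (0.36 log units; beyond the scatter), where a benzyl replaces a 4-(tert-butyl)phenyl on an aromatic carbon. That step sits on a core different from that of compound 1, so it bears on the present question only loosely.

Compound 4 `O=C1O/C(=C\Cn2cc(C3=CCCCC3)nn2)C(OCc2ccccc2)=C1OCc1ccccc1` differs from compound 1 by cyclohex-1-en-1-yl in place of benzyl on an aromatic carbon. Among the measured compounds shown here, since the only measured step offers weak guidance and points, if anywhere, toward a lower number when the benzyl is replaced, the expected step in this assay from compound 1 to compound 4 is a small lowering that stays within the scatter, a 1.4-fold lower number from compound 1 to compound 4 (0.15 log units; within the scatter). Compound 4 is therefore estimated to give 50000 nM in this assay, between 20000 nM and 100000 nM.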

Compound 4, half-maximal inhibitory concentration: 55600 nM
Compound 4: middle estimate off by 1.1-fold (0.05 log units), on the low side; the measured number falls inside the stated range.
By their numbers in this assay, from the lowest: compounds 2, 4 and 1 (each within the scatter of the next). At a limit, above all of these: compound 3.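

In this assay, putting cyclohex-1-en-1-yl in place of benzyl on the aromatic carbon of the five-membered ring with 3 nitrogen gives a 1.3-fold lower number from compound 1 to compound 4 (0.11 log units; within the scatter). On the core of compound 1, then, a six-membered non-aromatic ring with one double bond and a six-membered aromatic ring held through one extra carbon read alike at this position, something that could not be seen before, since this position had been changed only on the different core of compound 2 and compound 3. Nothing measured here explains why these two groups read alike.

From the compounds shown here alone, both groups contain only carbon, so it remains open whether an amine, a carboxylic acid or a longer chain at this position would move the number beyond the scatter on this core. Going by these compounds, it is also open whether the 4-(tert-butyl)phenyl of compound 2 would behave on the core of compound 1 as it does on its own.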